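The source may report more compounds than this note shows. Statements on the series, on what has been measured and on what is new or still open speak of the compounds shown alone.

Compound 1 `COc1ccc(NC(=O)COC(=O)/C=C/c2cc(OC)c(OCc3ccc(Cl)c(Cl)c3)c(OC)c2)cc1` is the reference point of the series. In a functional assay on BEL-7404 cells (Homo sapiens) for cytotoxicity, read by MTT assay, with a stated time of 72 h (on this read-out lower numbers stand for stronger inhibition and higher numbers for weaker inhibition), compound 1 gives 97800 nM, the only number shown so far. Compound 2 `COc1ccc(NC(=O)COC(=O)/C=C/c2cc(OC)c(OCc3ccccc3)c(OC)c2)cc1` carries a phenyl in place of the 3,4-dichlorophenyl on the saturated chain carbon bound to an oxygen on the aromatic ring. In this assay compound 2 returns > 200000 nM, which is a limit of the assay and not a number. The step of an at least 2.0-fold higher number from compound 1 to compound 2 (0.31 log units; beyond the scatter) therefore rests on (the limit of > 200000 nM in this assay, at which 1 of the 2 values shown sits). Compound 3 `COc1cc(/C=C/C(=O)OCC(=O)Nc2ccc(Cl)cc2)cc(OC)c1OCc1ccc(Cl)c(Cl)c1` differs from compound 1 at a different site: chloro in place of methoxy on an aromatic carbon, para to a large group. Among the compounds with values here, no measured step touches this position, and the one step known concerns the other end of the shared core. Compound 3 is expected to sit near 100000 nM, within a range from 40000 nM to 250000 nM. This estimate means a step of a 1.0-fold higher number from compound 1 to compound 3 (0.01 log units; within the scatter) that is expected to remain within the scatter.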

Compound 3, half-maximal inhibitory concentration: > 200000 nM
Compound 3: only a limit was reported; the forecaster's own chance of this, stated with the estimate: 30%; middle value at least 2.0-fold (0.30 log units) from the limit.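

The (4-methoxyphenyl)carbamoyl end of the shared core is not a silent site: on going to (4-chlorophenyl)carbamoyl, this assay shows an at least 2.0-fold higher number from compound 1 to compound 3 (0.31 log units; beyond the scatter). Compound 3 gives > 200000 nM, which is a limit of the assay and not a number. A change at this end thus moves the read-out as the change at the 3,4-dichlorophenyl does, but the two changes cannot be ranked and the true size of each stays open: the limit of > 200000 nM in this assay, at which 2 of the 3 values shown sit.

The compounds shown do not tell whether the methoxy is needed or the chloro alone counts against the read-out. Going by these compounds, how an amine, a carboxylic acid or a longer alkoxy chain would read at this position also remains open.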